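A few compounds are considered here, and "the series" means these few. Any claim that something is new, unique, unknown or untested is made for them only; others in the source may bear on it.

Measured compounds:

compound 1 `O=C(/C(=C\c1c(O)cc(O)cc1O)S(=O)(=O)c1ccccc1Br)c1ccc(Br)cc1` – 50000 nM
compound 2 `O=C(/C(=C\c1c(O)cc(O)cc1O)S(=O)(=O)c1ccccc1Br)c1ccc(Cl)cc1` – 50000 nM
compound 3 `Cc1ccc(S/C(=C/c2c[nH]c3ccc(Cl)cc23)C(=O)c2ccc(Cl)cc2)cc1` – 1000 nM

The three compounds were tested in a functional assay on DU-145 cells (Homo sapiens) for inhibition, read by trypan blue exclusion, with a stated time of 96 h; a higher number here means a weaker inhibitor of growth, a lower number a stronger inhibitor of growth. Compound 1 and compound 2 share one core and differ only by bromo in place of chloro on an aromatic carbon; this change gave no change at the digits printed from compound 2 to compound 1 (within the scatter). Compound 3 is built on a different core; the difference between the two cores is not broken down here. In this assay compound 3 gives 1000 nM, the lowest of the three numbers, and its gap to both compound 1 and compound 2 lies beyond the scatter.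

Compound 4 `Cc1ccc(S/C(=C/c2c[nH]c3ccc(Br)cc23)C(=O)c2ccc(Cl)cc2)cc1` has not yet been measured. It differs from compound 3 by bromo in place of chloro on an aromatic carbon. Among the measured compounds shown here, this is the same kind of change as the one from compound 2 to compound 1, but not the same: in compound 1 the bromo sits on a six-membered aromatic ring of carbon only, para to a large group, whereas in compound 4 it sits on a six-membered aromatic ring of carbon only that is part of a fused system of two rings, meta and para to the fused ring.

Because the step of no change at the digits printed from compound 2 to compound 1 (within the scatter) stayed within the scatter, compound 4 is expected to land close to compound 3, with an estimated step of no change at the digits printed from compound 3 to compound 4 (within the scatter). For compound 4 the estimated value in this assay is 1000 nM, with a range from 400 nM to 2500 nM.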

Compound 4, concentration for 50% growth inhibition: 1000 nM
The estimate for compound 4 equals the measured number at the digits printed; low and high end bracket the measured number.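

In this assay, bromo in place of chloro on an aromatic carbon of the ring that is part of a fused system gave no change at the digits printed from compound 3 to compound 4 (within the scatter). Set beside the earlier exchange on the core of compound 1, the result reads the same on both cores: the same change on two cores in this assay, no change at the digits printed (within the scatter) from compound 2 to compound 1 and no change at the digits printed (within the scatter) from compound 3 to compound 4, 1.0-fold (0.00 log units) apart, within the scatter of two such steps This shows that, for these two pairs, the exchange of one halogen for the other carried from one core to the other without a step beyond the scatter, but it rests on a single pair per core, with the halogen at a different place on each, and so it does not show that the exchange would stay this small on a further core or at another place on these cores, nor does it say why the two steps agree.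

The compounds shown leave open what would happen at the same place on the core of compound 3 with a group other than chloro or bromo, such as fluoro, methyl, methoxy, an amine or a carboxylic acid. They also leave open whether the chloro on the other aromatic ring of compound 3 could give way to bromo, or to any of these groups, with as small a step.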